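A Dimethylamino Swap on a Compound of Modest Activity

The source may hold more compounds than are shown below. What is called first, only, known or untested is meant among the compounds shown, and "the series" means these compounds.

In a functional assay on DU-145 cells (Homo sapiens) for inhibition, read by trypan blue exclusion, with a stated time of 96 h (a higher number here means a weaker inhibitor of growth, a lower number a stronger inhibitor of growth), compound 1 (`Cc1cc(C)cc(/C=C(/SCc2ccc(F)cc2)C(=O)c2ccc(Br)cc2)c1`) gives 10000 nM. Within the data shown here, compound 2 (`Cc1ccc(S/C(=C/c2ccc(Cl)cc2)C(=O)c2ccc(Br)cc2)cc1`), the only other measured compound, gives 10000 nM, so the two stand level within the scatter. Compound 3 (`CN(C)c1ccc(/C=C(/SCc2ccc(F)cc2)C(=O)c2ccc(Br)cc2)cc1`) keeps the core of compound 1 but carries 4-(dimethylamino)phenyl in place of 3,5-dimethylphenyl on a double-bonded chain carbon bound to a double-bonded chain carbon. Among the measured compounds shown here, no measured step in this assay speaks directly to this change, and the two values offer no trend to extend, so any forecast is tentative. A modest gain in growth inhibition is expected, although a result within the scatter of compound 1 at 10000 nM would be no surprise. The expected step is a 2.5-fold lower number from compound 1 to compound 3 (0.40 log units; beyond the scatter). For compound 3 the estimated value is 4000 nM, with an expected range from 800 nM to 15000 nM.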

Compound 3, concentration for 50% growth inhibition: 50000 nM
Compound 3: the middle estimate sits 13-fold (1.10 log units) below what was measured, outside the stated range (above it).
By their numbers in this assay, from the lowest: compounds 1 and 2 (each within the scatter of the next); then compound 3.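

In this assay, the swap of 3,5-dimethylphenyl for 4-(dimethylamino)phenyl on a double-bonded chain carbon bound to a double-bonded chain carbon gives a 5.0-fold higher number from compound 1 to compound 3 (0.70 log units; beyond the scatter) and so weakens growth inhibition. Among these compounds, this is the first reading at this position, and it shows that, for this pair at least, the group held there matters to the result. The change also replaces a group with no hydrogen-bond acceptor by one with a single acceptor, but nothing measured here explains the weaker result.

Because the swap alters both the group's substituents and their placement, the compounds shown cannot separate those two changes. From the compounds shown here alone, how 3-(dimethylamino)phenyl or 4-methoxyphenyl would read at this position remains open.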